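The source may hold more compounds than are shown below. What is called first, only, known or untested is meant among the compounds shown, and "the series" means these compounds.

Measured in a functional assay on thoracic aorta (Rattus norvegicus, strain Wistar), with a stated time of 15 min; a lower number here means that less compound is needed, a higher number that more compound is needed for the effect:
- compound 1, `CCOc1ccc(Br)cc1C(C)NC(=O)N(C)S(=O)(=O)c1ccc(Cl)cc1`: 55700 nM
- compound 2, `CCOc1ccc(Br)cc1C(C)NC(=O)N(C)S(=O)(=O)c1ccccc1`: 19800 nM
- compound 3, `COc1ccc(Br)cc1C(C)NC(=O)N(C)S(=O)(=O)c1ccc(Cl)cc1`: 19100 nM

Compound 1 gives the highest number of the three, so the most compound is needed for the effect; its neighbours in this assay are compound 2, reached by a 2.8-fold lower number from compound 1 to compound 2 (0.45 log units; beyond the scatter), and compound 3, reached by a 2.9-fold lower number from compound 1 to compound 3 (0.46 log units; beyond the scatter). Both steps are beyond the scatter, so compound 1 stands as the weakest of the measured set.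

Compound 4, `CCOc1ccc(Cl)cc1C(C)NC(=O)N(C)S(=O)(=O)c1ccc(Cl)cc1`, differs from compound 1 in one place: chloro in place of bromo on an aromatic carbon. Neither measured step bears directly on this change. The step to compound 2 concerns the chloro on the other aromatic ring; the step to compound 3 concerns the ethoxy group. Within the data shown here, both were modest and both lowered the number, but they touch other parts of the shared core, and no pair in the set exchanges one halogen for another. The change from bromo to chloro is small in what is counted, and without a relevant measured step nothing beyond the scatter can be expected in this assay.

The estimate for compound 4 is therefore 45000 nM, range 18000 nM to 110000 nM, which means an expected step of a 1.2-fold lower number from compound 1 to compound 4 (0.09 log units; within the scatter).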

Compound 4, half-maximal effective concentration: 14600 nM
Estimate against measurement, compound 4: 3.1-fold (0.49 log units) above; measured number below the stated range.
By their numbers in this assay, from the lowest: compounds 4, 3 and 2 (each within the scatter of the next); then compound 1.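

In this assay the aromatic carbon para to an ethoxy group responds to a single halogen exchange: the change of chloro in place of bromo gives a 3.8-fold lower number from compound 1 to compound 4 (0.58 log units; beyond the scatter), a modest step. Among these compounds, the earlier steps covered only the chloro on the other aromatic ring and the ethoxy group, so this is the first sign that the halogen on the ethoxy-bearing ring also moves the number, in the same direction as those two steps away from compound 1. No measurement at hand accounts for the effect of this exchange.

The compounds shown leave open how this position behaves with fluoro, with hydrogen, or with a group other than a halogen, such as a methoxy group, an amine or a carboxylic acid. They also leave open whether chloro in place of bromo gives a similar step alongside the methoxy group of compound 3, or alongside the hydrogen that replaces chloro in compound 2.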